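The source may report more compounds than this note shows. Statements on the series, on what has been measured and on what is new or still open speak of the compounds shown alone.

Working notes on the nitrofuran amide series.

Compound 1 `O=C(Nc1ccc(S(=O)(=O)N2CCC(Cl)CC2)cc1)c1ccc([N+](=O)[O-])o1` gives 800 nM in an assay on CHO-K1 cells for activation of DNA damage-inducible transcript 3 protein (Homo sapiens), read by a luciferase reporter; on this read-out higher numbers stand for an effect only at larger amounts of compound and lower numbers for an effect already at smaller amounts. Of the three numbers shown it is the highest, but neither gap reaches beyond the usual scatter: compound 2 `CC1CCN(S(=O)(=O)c2ccc(NC(=O)c3ccc([N+](=O)[O-])o3)cc2)CC1` gives 700 nM in this assay, and compound 3 `O=C(Nc1ccc(S(=O)(=O)N2CCC3(CCCCC3)CC2)cc1)c1ccc([N+](=O)[O-])o1` gives 700 nM. Among the measured compounds shown here, the only single-point step measured so far is a 1.1-fold lower number from compound 1 to compound 2 (0.06 log units; within the scatter), a change on a saturated ring carbon that left the number where it was.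

Compound 4 `O=C(Nc1ccc(S(=O)(=O)C2CCCCC2)cc1)c1ccc([N+](=O)[O-])o1` has not yet been measured. It differs from compound 1 by cyclohexyl in place of 4-chloropiperidin-1-yl on a sulfonyl sulfur. For the measured compounds named here, no measured step covers exactly this exchange. What the data do show is that three different groups on the sulfonyl sulfur, in compounds 1, 2 and 3, all sit within the scatter of one another. On that basis the expected step of no change at the digits printed from compound 1 to compound 4 (within the scatter) for compound 4 is none beyond the scatter in this assay, with the range widened for the untested exchange. Compound 4 is therefore estimated at 800 nM in this assay, between 300 nM and 2500 nM.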

Compound 4, concentration for half-maximal activity: 700 nM
Estimate against measurement, compound 4: 1.1-fold (0.06 log units) above; low and high end bracket the measured number.
By their numbers in this assay, from the lowest: compounds 2, 3, 4 and 1 (each within the scatter of the next).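

Compound 4 puts a six-membered non-aromatic ring of carbon only on the sulfonyl sulfur, whereas the rings in compounds 1, 2 and 3 each hold a nitrogen. In this assay the exchange gives a 1.1-fold lower number from compound 1 to compound 4 (0.06 log units; within the scatter) and also no change at the digits printed from compound 2 to compound 4 (within the scatter) in the matching exchange for 4-methylpiperidin-1-yl. Among these compounds, then, neither the ring nitrogen nor the chlorine of compound 1 is needed for the number to stay within the scatter, and nothing at hand explains this.

On these data alone, all four compounds carry a saturated ring on the sulfonyl sulfur, so it remains open whether the number holds with a phenyl ring, a straight butyl chain or a simple dimethylamino group in that place. Also open, as far as these compounds go, is the effect of a carboxylic acid on the saturated ring.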